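A few compounds are considered here, and "the series" means these few. Any claim that something is new, unique, unknown or untested is made for them only; others in the source may bear on it.

Measured so far in an assay on FRT-Jurkat cells for inhibition of nuclear factor NF-kappa-B complex (Homo sapiens), read by flow cytometry, with a stated time of 24 h, tested at 10 uM; a lower number here means less inhibition, a higher number more inhibition at the concentration tested (going by the name of the read-out):

compound 1 `CCCCCc1ccc(Nc2ccc3c(c2)C(=O)N(C2CCC(=O)NC2=O)C3=O)cc1` gives 12%
compound 2 `O=C1CCC(N2C(=O)c3ccc(Nc4ccccc4)cc3C2=O)C(=O)N1` gives 6%
compound 3 `CC(C)c1ccc(Nc2ccc3c(c2)C(=O)N(C2CCC(=O)NC2=O)C3=O)cc1` gives 11%

Compound 3 holds the second highest of the three numbers. Its nearest neighbour is compound 1, with a number 1 percentage points lower from compound 1 to compound 3 (within the scatter); its furthest is compound 2, with a number 5 percentage points higher from compound 2 to compound 3 (within the scatter). Neither gap is anything more than repeat scatter, and the same holds for a number 6 percentage points lower from compound 1 to compound 2 (within the scatter), so across all three compounds the substituent on this aromatic carbon, whether pentyl, isopropyl or hydrogen, has left the read-out flat.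

Compound 4 `CCCc1ccc(Nc2ccc3c(c2)C(=O)N(C2CCC(=O)NC2=O)C3=O)cc1` differs from compound 3 only in this way: propyl in place of isopropyl on an aromatic carbon. The relevant comparisons are the chain swaps already seen, from pentyl to isopropyl and from hydrogen to isopropyl, none of which moved this assay beyond its noise. A straight three-carbon chain in place of a branched one is a smaller change than either, so no step beyond the scatter is expected here in either direction: the expected step is no change at the digits printed from compound 3 to compound 4 (within the scatter).

Compound 4 is therefore estimated at 11% in this assay, with a range of 3% to 19%.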

Compound 4, a percentage reported as inhibition, at one concentration (the size of the read-out at that concentration, not a potency): 10%
For compound 4 the middle estimate is 1 percentage points above the measured one, within the range that was stated.
By their numbers in this assay, from the lowest: compounds 2, 4, 3 and 1 (each within the scatter of the next).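

In this assay, branching at this position, para to a large group, does not register: propyl in place of isopropyl gives a number 1 percentage points lower from compound 3 to compound 4 (within the scatter), so two groups with the same atoms joined differently cannot be told apart. The straight propyl chain also stands within the scatter of both other substituents, with a number 4 percentage points higher from compound 2 to compound 4 (within the scatter) for propyl in place of hydrogen and a number 2 percentage points lower from compound 1 to compound 4 (within the scatter) for the shorter chain in place of pentyl, so the hydrogen, propyl, isopropyl and pentyl compounds form one undivided group. No available evidence bears on this lack of separation.

The substituents shown at this carbon are only hydrogen and plain alkyl groups. Going by these compounds, whether an amine, a carboxylic acid or a chain longer than pentyl here would give a step beyond the scatter remains open.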